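The compounds below may be only part of what the source reports. "The series", "measured", "known", "first", "only" and "open" are said of these compounds alone.

Measured compounds, all in a functional assay on CRL2813 cells (Homo sapiens) for cytotoxicity, read by sulforhodamine B assay, with a stated time of 5 days; a lower number here means a stronger inhibitor, a higher number a weaker inhibitor:
- compound 1, `O=C(Nc1cccc(C(F)(F)F)c1)N[C@H]1CC[C@H](Oc2ccc(C(F)(F)F)cc2)CC1`, gives 460 nM
- compound 2, `O=C(Nc1cccc(C(F)(F)F)c1)N[C@H]1CC[C@H](Oc2ccc(OC(F)(F)F)cc2)CC1`, gives 690 nM
- compound 3, `O=C(Nc1cccc(C(F)(F)F)c1)N[C@H]1CC[C@H](Oc2ccccc2C(F)(F)F)CC1`, gives 1400 nM

Compound 3 stands at the highest number of the three, beyond the scatter from both of the others: the step of a 3.0-fold higher number from compound 1 to compound 3 (0.48 log units; beyond the scatter) is the larger gap, and the nearest neighbour is compound 2, whose number is lower by about half. The step of a 1.5-fold higher number from compound 1 to compound 2 (0.18 log units; within the scatter) shows that exchanging trifluoromethyl for trifluoromethoxy on the aryl ether leaves the number essentially where it was.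

Compound 4, `O=C(Nc1cccc(C(F)(F)F)c1)N[C@H]1CC[C@H](Oc2ccc(Cl)cc2)CC1`, is not yet measured. It differs from compound 3 by 4-chlorophenyl in place of 2-(trifluoromethyl)phenyl on an oxygen on a saturated carbon. The step that bears most directly on it is a 3.0-fold higher number from compound 1 to compound 3 (0.48 log units; beyond the scatter), which shows a modest but real loss in going from the 4-(trifluoromethyl)phenyl ether to the 2-(trifluoromethyl)phenyl ether. Compound 4 reverses that arrangement but with a different substituent, so the return is expected to be partial rather than exact: the expectation is a step of a 2.3-fold lower number from compound 3 to compound 4 (0.37 log units; beyond the scatter) towards lower numbers, landing near compounds 1 and 2. Compound 4 is therefore estimated at 600 nM, with a range from 250 nM to 1400 nM.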

Compound 4, half-maximal inhibitory concentration: 2000 nM
Estimate against measurement, compound 4: 3.3-fold (0.52 log units) below; measured number above the stated range.
By their numbers in this assay, from the lowest: compounds 1 and 2 (each within the scatter of the next); then compounds 3 and 4 (each within the scatter of the next).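

Chloro is not interchangeable with the two fluorinated groups on the aromatic carbon of this aryl ether: in this assay the exchange for trifluoromethyl gives a 4.3-fold higher number from compound 1 to compound 4 (0.64 log units; beyond the scatter) and the exchange for trifluoromethoxy gives a 2.9-fold higher number from compound 2 to compound 4 (0.46 log units; beyond the scatter) in the same direction, whereas the earlier exchange between those two fluorinated groups stayed within the scatter. The change of 2-(trifluoromethyl)phenyl to 4-chlorophenyl gives a 1.4-fold higher number from compound 3 to compound 4 (0.15 log units; within the scatter) and so leaves these two ethers indistinguishable, which means that the low numbers of compound 1 and compound 2 do not follow from any group placed as in those compounds, but depend on which group it is. Nothing available here accounts for the difference between chloro and the fluorinated groups.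

Still open, as far as these compounds go, is how the number responds on this aryl ether to groups such as fluoro, methyl, methoxy or nitrile, and whether the unsubstituted phenyl ether sits with compound 1 and compound 2 or with compound 3 and compound 4. Also open, from the compounds shown here alone, is whether an amine or a carboxylic acid on the same ring is tolerated on the shared core.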